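A few compounds are considered here, and "the series" means these few. Any claim that something is new, unique, unknown or untested is made for them only; others in the source may bear on it.

Measured so far:
Compound 1, `COc1cccc(-c2ccc([C@H]3S[C@@H](C)C(=O)Nc4c3c(C)nn4-c3ccccc3C)cc2)c1`: 41%
Compound 2, `Cc1ccccc1-n1nc(C)c2c1NC(=O)[C@H](C)S[C@@H]2c1ccc(-c2cc3ccccc3o2)cc1`: 17%

In an assay on isolated protein for agonist activity at Bile acid receptor (Homo sapiens), read by AlphaScreen, with a stated time of 30 min (a lower number here means a smaller maximal response, a higher number a larger maximal response), compound 1 gives 41%, while compound 2 gives 17%. Going by the values given here, compound 2 therefore holds the lower of the two numbers; its only neighbour is compound 1, and the step between them is a number 24 percentage points lower from compound 1 to compound 2 (beyond the scatter), beyond the scatter.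

Compound 3, `Cc1ccccc1-n1nc(C)c2c1NC(=O)[C@H](C)S[C@@H]2c1ccc(-c2ccsc2)cc1`, has not yet been measured in this assay. It differs from compound 2 in one place: thiophen-3-yl in place of 1-benzofuran-2-yl on an aromatic carbon. Among the compounds with values here, the single measured step bears on this change only in part: in that step the 1-benzofuran-2-yl group entered in place of 3-methoxyphenyl and the number fell by a number 24 percentage points lower from compound 1 to compound 2 (beyond the scatter). Here the same 1-benzofuran-2-yl group leaves again, now replaced by thiophen-3-yl rather than by 3-methoxyphenyl. Because the arrival of this group went with a number 24 percentage points lower from compound 1 to compound 2 (beyond the scatter), its departure is expected to move the number back upward, though with a different group entering the size is uncertain. The step of a number 13 percentage points higher from compound 2 to compound 3 (beyond the scatter) is expected to be modest and upward. Compound 3 is estimated at 30%, within a range of 12% to 50%.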

Compound 3, largest response reached (reported as efficacy), in percent of the reference or control that the assay uses: 68%
Estimate against measurement, compound 3: 38 percentage points below, and the stated range ends below it.
By their numbers in this assay, from the lowest: compound 2; then compound 1; then compound 3.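

In this assay, the aromatic carbon para to a large group proves able to carry the response upward as well as downward: thiophen-3-yl in place of 1-benzofuran-2-yl gives a number 51 percentage points higher from compound 2 to compound 3 (beyond the scatter), and thiophen-3-yl in place of 3-methoxyphenyl gives a number 27 percentage points higher from compound 1 to compound 3 (beyond the scatter). The earlier pair showed only a fall between two larger substituents, whereas these steps place compound 3 beyond the scatter above both of the others, so the choice of group here can shift the maximal response widely while the rest of the molecule stays the same. Nothing measured here accounts for the size or direction of these steps.

The change from 1-benzofuran-2-yl to thiophen-3-yl swaps oxygen for sulfur and removes the six-membered aromatic ring in one step, leaving open which of these goes with the higher response. Thiophen-2-yl, furan-3-yl or an unsubstituted phenyl at the same place would help to separate these readings, and whether thiophen-3-yl keeps its advantage with other changes to the shared core also remains open.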